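The source may report more compounds than this note shows. Statements on the series, on what has been measured and on what is new or still open speak of the compounds shown alone.

Measured so far in an assay for inhibition of histone deacetylase 4 (Homo sapiens); a higher number here means a weaker inhibitor, a lower number a stronger inhibitor:
Compound 1 `O=C(c1ccc(-c2nc(Cc3cccs3)no2)s1)C(F)(F)F` gives 15 nM.
Compound 2 `O=C(c1ccc(-c2nc(-c3ccc(F)cc3F)no2)s1)C(F)(F)F` gives 120 nM.

Compound 1 has the lowest number of the two measured compounds; its nearest neighbour is compound 2, reached by an 8.0-fold higher number from compound 1 to compound 2 (0.90 log units; beyond the scatter), where a 2,4-difluorophenyl replaces the (thiophen-2-yl)methyl group on an aromatic carbon of the shared core. Compound 3 `O=C(c1ccc(-c2nc(CS(=O)(=O)c3cccs3)no2)s1)C(F)(F)F` has not yet been measured in this assay. It differs from compound 1 in one place: (thiophen-2-yl)sulfonyl in place of thiophen-2-yl on a saturated chain carbon bound to an aromatic carbon. Going by the values given here, no measured step involves a sulfonyl, and the step from compound 1 to compound 2 concerns another kind of change, so it bears only loosely on this one. The expectation is therefore a modest step, more likely upward than downward, with wide uncertainty. Compound 3 is expected to give 40 nM, in a range from 10 nM to 160 nM. This estimate means a 2.7-fold higher number from compound 1 to compound 3 (0.43 log units; beyond the scatter).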

Compound 3, half-maximal inhibitory concentration: 35 nM
Beside the measured number, compound 3's estimate is 1.1-fold (0.06 log units) above it; the measured number falls inside the stated range.
By their numbers in this assay, from the lowest: compound 1; then compound 3; then compound 2.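

In this assay, the saturated chain carbon bound to an aromatic carbon accepts (thiophen-2-yl)sulfonyl in place of thiophen-2-yl at the cost of only a modest change, a 2.3-fold higher number from compound 1 to compound 3 (0.37 log units; beyond the scatter). Going by these compounds alone, the earlier step, an 8.0-fold higher number from compound 1 to compound 2 (0.90 log units; beyond the scatter), replaced the whole (thiophen-2-yl)methyl group, whereas this one keeps the chain carbon and the thiophene ring and inserts a sulfonyl, so it is the first reading of a change made within that group. No measurement is available that would explain the step.

The compounds shown cannot separate the contribution of the sulfonyl oxygens from that of the extra sulfur in the chain, which a thioether or a sulfoxide in the same place would address. On these data alone, how an amine or a carboxylic acid on that chain would read remains open.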